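The compounds below may be only part of what the source reports. "The series", "measured", "known", "first", "only" and "open" are said of these compounds alone.

Compounds measured so far in an assay for inhibition of HSP60/HSP10 (Homo sapiens), with a stated time of 60 min; a lower number here means a stronger inhibitor, a higher number a weaker inhibitor:

compound 1, `COc1c(Br)cccc1C(=O)Nc1ccccc1`: > 100000 nM, a limit of the assay
compound 2, `O=C(Nc1ccc(Sc2nc3ccccc3s2)c(Cl)c1)c1cccc(Br)c1`: > 100000 nM, a limit of the assay

Both measured compounds sit at the same limit, so that neither gives a number: the limit of > 100000 nM in this assay, at which 2 of the 2 values shown sit. Within the data shown here, compound 2 therefore has no measured position other than this limit, and no step between measured compounds is available for this series; nothing is known about how a change at the carbonyl-attached ring shifts the read-out here.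

Compound 3, `O=C(Nc1ccc(Sc2nc3ccccc3s2)c(Cl)c1)c1ccccc1O`, is the next compound to be measured in this assay. It differs from compound 2 in one place: 2-hydroxyphenyl in place of 3-bromophenyl on a carbonyl carbon. The shared core of compound 2 and compound 3 is kept; only the ring on the carbonyl carbon changes.

Among the measured compounds shown here, with no measured step to lean on and compound 2 known only as a limit, the expectation for compound 3 is that the read-out most likely stays at or near the limit, and the expected step from compound 2 to compound 3 is a number no higher from compound 2 to compound 3 (the limit leaves the size open). The estimate for compound 3 in this assay is 100000 nM, with a range from 10000 nM to 500000 nM.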

Compound 3, half-maximal inhibitory concentration: > 100000 nM
Compound 3: a limit, no number; the forecaster's own chance of this, stated with the estimate: 75%; the middle value sits exactly at the limit.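

In this assay, no step can be read from compound 2 to compound 3, since both stop at a limit of the assay and give no number: the limit of > 100000 nM in this assay, at which 3 of the 3 values shown sit.

The compounds shown leave open whether exchanging 3-bromophenyl for 2-hydroxyphenyl on the carbonyl carbon shifts the read-out at all, and how any of these compounds ranks against the others.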